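From hexyl to hexyloxy in a small inhibitor set

The source may report more compounds than this note shows. Statements on the series, on what has been measured and on what is new or still open speak of the compounds shown alone.

Measured in a functional assay on brain (Rattus norvegicus, strain Wistar) for inhibition; a lower number here means a stronger inhibitor, a higher number a weaker inhibitor:
Compound 1 `Cc1[nH]c(=O)n(C2CCCCC2)c1-c1ccccc1` gives (47600 nM)
Compound 2 `Cc1[nH]c(=O)n(C2CCCCC2)c1-c1ccc(OC(C)C)cc1` gives (13000 nM)
Compound 3 `CCCCCCc1ccc(-c2c(C)[nH]c(=O)n2C2CCCCC2)cc1` gives (13700 nM)

On these numbers compound 3 belongs to the lower pair. It cannot be told apart from its isopropoxy analogue (a 1.1-fold higher number from compound 2 to compound 3 (0.02 log units; within the scatter)) and lies clearly under the unsubstituted compound (a 3.5-fold lower number from compound 1 to compound 3 (0.54 log units; beyond the scatter)). Compound 4 `CCCCCCOc1ccc(-c2c(C)[nH]c(=O)n2C2CCCCC2)cc1` carries hexyloxy in place of hexyl on an aromatic carbon. Among the compounds with values here, no measured step isolates this oxygen. The nearest evidence is the exchange of isopropoxy for hexyl (a 1.1-fold higher number from compound 2 to compound 3 (0.02 log units; within the scatter)), which stayed within the scatter, so no step beyond the scatter is expected in this assay. The estimated step is small (a 1.4-fold lower number from compound 3 to compound 4 (0.14 log units; within the scatter)). For compound 4 the expected value is (10000 nM), with an estimated range from (4000 nM) to (25000 nM).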

Compound 4, half-maximal inhibitory concentration: 8500 nM
For compound 4 the middle estimate is 1.2-fold (0.07 log units) above the measured one; the range from low to high includes it.
By their numbers in this assay, from the lowest: compounds 4, 2 and 3 (each within the scatter of the next); then compound 1.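

In this assay, the oxygen joining the chain to the aromatic ring can now be read on its own, and hexyloxy in place of hexyl stays within the scatter (a 1.6-fold lower number from compound 3 to compound 4 (0.21 log units; within the scatter)). Hexyl in place of isopropyl on that oxygen also stays within the scatter (a 1.5-fold lower number from compound 2 to compound 4 (0.18 log units; within the scatter)), while hexyloxy in place of hydrogen lies beyond it (a 5.6-fold lower number from compound 1 to compound 4 (0.75 log units; beyond the scatter)). All three groups at this position thus give lower numbers than hydrogen, and none separates from another.

No further data bear on this result. From the compounds shown here alone, whether an amine, a carboxylic acid or a chain longer than hexyl would separate from these groups remains open.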